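Compound 3 to Compound 4: An Acid-Bearing Sulfonyl Aryl Group

This account rests on a few compounds, and the source may have more. Where it says the series, first, only, none or still open, it means among the compounds named here.

In a functional assay on PC-3 cells (Homo sapiens) for inhibition (on this read-out higher numbers stand for weaker inhibition and lower numbers for stronger inhibition), the three measured compounds give these numbers:
compound 1 `COc1cc2nc(N3CCN(C(=O)c4ccc(C(C)(C)C)cc4)CC3)nc(N)c2cc1OC`, 47000 nM
compound 2 `COc1cc2nc(N3CCN(S(=O)(=O)c4ccc(Br)cc4)CC3)nc(N)c2cc1OC`, 20000 nM
compound 3 `COc1cc2nc(N3CCN(S(=O)(=O)c4ccc(C(F)(F)F)cc4)CC3)nc(N)c2cc1OC`, 27000 nM

Compound 3 stands second highest of the three numbers; compound 2 lies nearest and compound 1 furthest, both gaps within the scatter. Within the data shown here, the only step that exchanges a substituent on the sulfonyl aryl ring, a 1.4-fold higher number from compound 2 to compound 3 (0.13 log units; within the scatter), stays within the scatter. Compound 4 `COc1cc2nc(N3CCN(S(=O)(=O)c4cc(F)c(Cl)c(C(=O)O)c4)CC3)nc(N)c2cc1OC` differs from compound 3 in one place: 3-carboxy-4-chloro-5-fluorophenyl in place of 4-(trifluoromethyl)phenyl on a sulfonyl sulfur. Among the measured compounds shown here, no measured step exchanges a whole substituted phenyl carrying a carboxy group, so the data give no direction for this change, and the expectation rests on the flatness seen so far. Compound 4 is therefore expected at 35000 nM, within 10000 nM to 120000 nM, which would mean a 1.3-fold higher number from compound 3 to compound 4 (0.11 log units; within the scatter).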

Compound 4, half-maximal inhibitory concentration: 56000 nM
Compound 4: the middle estimate sits 1.6-fold (0.20 log units) below what was measured, and the stated range covers the measured number.
By their numbers in this assay, from the lowest: compounds 2, 3, 1 and 4 (each within the scatter of the next, the first and the last beyond it).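

In this assay, this position proves not to be flat: 3-carboxy-4-chloro-5-fluorophenyl in place of 4-(trifluoromethyl)phenyl on the sulfonyl sulfur gives a 2.1-fold higher number from compound 3 to compound 4 (0.32 log units; beyond the scatter), and in place of 4-bromophenyl it gives a 2.8-fold higher number from compound 2 to compound 4 (0.45 log units; beyond the scatter). Both steps are modest, but they pass the scatter and point to weaker inhibition, whereas the earlier exchange, a 1.4-fold higher number from compound 2 to compound 3 (0.13 log units; within the scatter), did not. No supporting measurement bears on this result. Going by these compounds, whether the step belongs to the carboxy, chloro or fluoro substituent stays open, as does how a methyl ester or primary amide would read in place of the carboxylic acid.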